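This account rests on a few compounds, and the source may have more. Where it says the series, first, only, none or still open, it means among the compounds named here.

Compound 2 `COc1ccc([C@H]2CC(=O)N(c3cccc(C#N)c3)C2)cc1OC1CCCC1` is one of two compounds tested in a functional assay on HEK293 cells (Homo sapiens) for cytotoxicity; on this read-out lower numbers stand for higher toxicity in this test and higher numbers for lower toxicity in this test. In this assay compound 2 reaches only the limit of > 10000 nM. Compound 1 `COc1ccc([C@H]2CC(=O)N(Cc3cccc(C#N)c3)C2)cc1OC1CCCC1` likewise gives only the limit of > 10000 nM. Among the measured compounds shown here, the step that the two limits leave unreadable from compound 1 to compound 2 therefore cannot be read, and the only evidence is the limit of > 10000 nM in this assay, at which 2 of the 2 values shown sit. Compound 3 `COc1ccc([C@H]2CC(=O)N(c3cccnc3)C2)cc1OC1CCCC1` differs from compound 2 in one place: pyridin-3-yl in place of 3-cyanophenyl on an amide-type nitrogen in a ring. For the measured compounds named here, no measured step bears on this change, so nothing beyond the scatter is expected. Compound 3 is expected to give 15000 nM, within 8000 nM to 50000 nM. The expected step is a step that the limit leaves unreadable from compound 2 to compound 3.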

Compound 3, half-maximal cytotoxic concentration: > 10000 nM
Compound 3: only a limit was reported (the forecaster's own chance of this, stated with the estimate: 80%); the middle value lies beyond the limit too.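

Among the compounds shown here, compound 3 gives only the limit of > 10000 nM and so no step among compound 1, compound 2 and compound 3 can be read. The compounds shown leave open whether the groups on the amide-type nitrogen differ at all in this assay beyond this limit.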